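A few compounds are considered here, and "the series" means these few. Any claim that something is new, unique, unknown or untested is made for them only; others in the source may bear on it.

Of the compounds shown here, three that share one core have been tested in a functional assay on A549 cells (Homo sapiens) for antiproliferative activity, read by MTT assay; a higher number here means a weaker inhibitor, a lower number a stronger inhibitor. Compound 1 `O=C1N=C(N2CCC[C@H]2C(=O)Nc2ccc3ncnc(Nc4cccc(Cl)c4)c3c2)S/C1=C/c1ccc(Br)s1` carries a 5-bromothiophen-2-yl group on a double-bonded chain carbon bound to a double-bonded ring carbon. In this assay compound 1 reaches only a limit, > 50000 nM. Compound 2 `COc1ccccc1/C=C1/SC(N2CCC[C@H]2C(=O)Nc2ccc3ncnc(Nc4cccc(Cl)c4)c3c2)=NC1=O` has 2-methoxyphenyl at that place instead. In this assay compound 2 again gives only a limit, > 50000 nM. Compound 3 `O=C1N=C(N2CCC[C@H]2C(=O)Nc2ccc3ncnc(Nc4cccc(Cl)c4)c3c2)S/C1=C/c1ccccc1[N+](=O)[O-]` carries 2-nitrophenyl there. In this assay compound 3 likewise gives only a limit, > 50000 nM. Compound 3 therefore stands at the limit together with the other two, and the steps a step that the two limits leave unreadable from compound 1 to compound 2, a step that the two limits leave unreadable from compound 1 to compound 3 and a step that the two limits leave unreadable from compound 2 to compound 3 cannot be sized, since every value sits at the limit of > 50000 nM in this assay, at which 3 of the 3 values shown sit. Compound 4 `O=C1N=C(N2CCC[C@H]2C(=O)Nc2ccc3ncnc(Nc4cccc(Cl)c4)c3c2)S/C1=C/c1ccc2ccccc2n1` differs from compound 3 by quinolin-2-yl in place of 2-nitrophenyl on a double-bonded chain carbon bound to a double-bonded ring carbon. Going by the values given here, no measured step shows what a change of this kind does, and the three measured steps give no direction beyond the scatter because each of them ends at the limit of > 50000 nM in this assay, at which 3 of the 3 values shown sit. The step from compound 3 to compound 4 is therefore expected to be a step that the limit leaves unreadable from compound 3 to compound 4, with wide uncertainty. Compound 4 is expected to give about 60000 nM, within 5000 nM to 200000 nM, and most likely only a limit once more.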

Compound 4, half-maximal inhibitory concentration: > 50000 nM
Compound 4: only a limit was reported (the forecaster's own chance of this, stated with the estimate: 75%); the middle value lies beyond the limit too.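

The steps from compound 1, compound 2 and compound 3 to compound 4 cannot be read, because all four compounds give only a limit: the limit of > 50000 nM in this assay, at which 4 of the 4 values shown sit.

The compounds shown leave open whether swapping the group on a double-bonded chain carbon bound to a double-bonded ring carbon changes antiproliferative activity at all, and by how much.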